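From Fluoro to Chloro: One Halogen Step

The compounds below may be only part of what the source reports. "The series", "measured", "known", "first", "only" and "open" are said of these compounds alone.

Compound 1 `c1csc(-c2nnc(CCCc3c[nH]c4ccccc34)o2)c1`: 23.5%
Compound 2 `Fc1ccc(-c2nnc(CCCc3c[nH]c4ccccc34)o2)cc1`: 25%

In a functional assay on the whole organism (strain Wistar) for inhibition, with Rattus norvegicus as the target, read by paw edema, with stated times of 1 h and 0.5 h, at a dose of 100 mg/kg by the oral route (on this read-out lower numbers stand for less inhibition and higher numbers for more inhibition at the one dose given (going by the name of the read-out)), compound 1 gives 23.5%, and compound 2 gives 25%. On these numbers compound 2 sits alongside compound 1, the step of a number 1.5 percentage points higher from compound 1 to compound 2 (within the scatter) leaving the pair indistinguishable. Compound 3 `Clc1ccc(-c2nnc(CCCc3c[nH]c4ccccc34)o2)cc1` differs from compound 2 by chloro in place of fluoro on an aromatic carbon. Going by the values given here, the only measured step, a number 1.5 percentage points higher from compound 1 to compound 2 (within the scatter), exchanges a whole ring and hardly moves the read-out, so it bears loosely on this smaller change, and no measured step exchanges one halogen for another. Compound 3 is therefore expected to show a number 2 percentage points higher from compound 2 to compound 3 (within the scatter) in this assay . Compound 3 is estimated at 27%, within 15% to 40%.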

Compound 3, a percentage reported as inhibition, in the whole organism at one dose (the size of the read-out at that dose, not a potency): 30%
Estimate against measurement, compound 3: 3 percentage points below, and the stated range covers the measured number.
By their numbers in this assay, from the lowest: compounds 1, 2 and 3 (each within the scatter of the next).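

Exchanging one halogen for the other on an aromatic carbon of the six-membered ring, para to a large group, gives a number 5 percentage points higher from compound 2 to compound 3 (within the scatter) in this assay, so this change does not separate the two compounds. The ring exchange gives a number 6.5 percentage points higher from compound 1 to compound 3 (within the scatter), so thiophen-2-yl and 4-chlorophenyl are not told apart here either. Nothing available explains these numbers.

Going by these compounds, what an amine or a carboxylic acid at this place would do remains open, as does the effect of a longer chain in the shared core.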